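This account rests on a few compounds, and the source may have more. Where it says the series, first, only, none or still open, it means among the compounds named here.

Compound 1 `O=C(NC(=S)N1CCc2c(OCCCCCOc3ccc(Cl)cc3)cccc21)c1ccc(C(F)(F)F)cc1` gives 32700 nM in an ADME assay on Huh-7 cells (Homo sapiens) for cytotoxicity; on this read-out lower numbers stand for higher toxicity in this test and higher numbers for lower toxicity in this test. Compound 2 `Cc1ccc(C(=O)NC(=S)N2CCc3c(OCCCCCOc4ccc(Cl)cc4)cccc32)cc1` gives > 50000 nM in this assay, a limit of the assay. Compound 3 `O=C(NC(=S)N1CCc2c(OCCCCCOc3ccc(Cl)cc3)cccc21)c1ccc2ccccc2c1` gives > 50000 nM in this assay, again a limit.

Compound 3 thus stands at the limit of > 50000 nM in this assay, at which 2 of the 3 values shown sit, with no number of its own. Compound 4 `O=C(NC(=S)N1CCc2c(OCCCCCOc3ccc(Cl)cc3)cccc21)c1ccno1` carries 1,2-oxazol-5-yl in place of naphthalen-2-yl on a carbonyl carbon. The step of an at least 1.5-fold higher number from compound 1 to compound 3 (0.18 log units; that floor lies within the scatter) shows that exchanging the aryl group on the carbonyl carbon moved the read-out to the limit, while a step that the two limits leave unreadable from compound 2 to compound 3 remains unreadable. Compound 4 is therefore expected to stay near the limit, with a number no higher from compound 3 to compound 4 (the limit leaves the size open) as the estimated step. Compound 4 is estimated at 50000 nM, within 20000 nM to 150000 nM.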

Compound 4, half-maximal cytotoxic concentration: 37100 nM
Compound 4: middle estimate off by 1.3-fold (0.13 log units), on the high side; low and high end bracket the measured number.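

The 1,2-oxazol-5-yl group on the carbonyl carbon shows that a five-membered aromatic ring with hetero atoms still gives a measurable number in this assay. Against the two aryl groups at the limit, the change reads as an at least 1.3-fold lower number from compound 3 to compound 4 (0.12 log units; that floor lies within the scatter) and as an at least 1.3-fold lower number from compound 2 to compound 4 (0.12 log units; that floor lies within the scatter), both resting on floors only: the limit of > 50000 nM in this assay, at which 2 of the 4 values shown sit. Against 4-(trifluoromethyl)phenyl it reads as a 1.1-fold higher number from compound 1 to compound 4 (0.05 log units; within the scatter), so these two groups are not told apart here.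

The step between the two compounds at the limit cannot be read. From the compounds shown here alone, how a non-aromatic group on this carbonyl carbon, such as cyclohexyl or an aminomethyl group, would read remains open.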